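Sulfonyl aryl variation in the shared-core sulfonamide series

The source may report more compounds than this note shows. Statements on the series, on what has been measured and on what is new or still open speak of the compounds shown alone.

Three compounds on one shared core have numbers in an assay on MDA-MB-231 cells for binding affinity to C-X-C chemokine receptor type 4 (Homo sapiens), read by microscopy, with stated times of 10 min and 30 min; a higher number here means that more compound is needed for the effect, a lower number that less compound is needed. Compound 1 `Cc1cccc(S(=O)(=O)NCc2ccc(CNC(=O)c3ccc(CNc4ncccn4)cc3)cc2)c1` gives 100 nM. Compound 2 `O=C(NCc1ccc(CNS(=O)(=O)c2cccc(C(F)(F)F)c2)cc1)c1ccc(CNc2ncccn2)cc1` gives 1000 nM, the highest of the three numbers; the step of a 10-fold higher number from compound 1 to compound 2 (1.00 log units; beyond the scatter) is beyond the scatter, and the step of a 1000-fold lower number from compound 2 to compound 3 (3.00 log units; beyond the scatter) is larger still. Compound 3 `O=C(NCc1ccc(CNS(=O)(=O)c2ccccc2)cc1)c1ccc(CNc2ncccn2)cc1` gives 1 nM, the lowest number in the set, and the step of a 100-fold lower number from compound 1 to compound 3 (2.00 log units; beyond the scatter) is also beyond the scatter. Across these three, an unsubstituted ring on the sulfonyl sulfur gives the lowest number, and either group on that ring raises it.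

Compound 4 `O=C(NCc1ccc(CNS(=O)(=O)c2ccc3c(c2)CCO3)cc1)c1ccc(CNc2ncccn2)cc1` differs from compound 2 only on the sulfonyl sulfur: a group of 9 heavy atoms (8 carbon, 1 oxygen; one five-membered non-aromatic ring with 1 hetero atom, one six-membered aromatic ring of carbon only) in place of a group of 10 heavy atoms (7 carbon, 3 fluorine; one six-membered aromatic ring of carbon only), on a sulfonyl sulfur. For the measured compounds named here, the steps that bear on this change are a 1000-fold lower number from compound 2 to compound 3 (3.00 log units; beyond the scatter), where removing the trifluoromethyl gives a large drop, and a 10-fold higher number from compound 1 to compound 2 (1.00 log units; beyond the scatter), where the trifluoromethyl sits higher than methyl. The entering group keeps a substituted ring, so the full drop seen for compound 3 is not expected, but a downward step beyond the scatter is; the expected step is a 5.0-fold lower number from compound 2 to compound 4 (0.70 log units; beyond the scatter). Compound 4 is therefore estimated at 200 nM in this assay, with a range of 20 nM to 2000 nM.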

Compound 4, effective concentration (reported as EC, without a stated level of effect): 1000 nM
Compound 4: the middle estimate sits 5.0-fold (0.70 log units) below what was measured; measured number inside the range.
By their numbers in this assay, from the lowest: compound 3; then compound 1; then compounds 2 and 4 (each within the scatter of the next).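

In this assay, the group with one five-membered non-aromatic ring carries no fluorine, yet on the sulfonyl sulfur it gives no change at the digits printed from compound 2 to compound 4 (within the scatter), so a number at the level of compound 2 does not require the 3-(trifluoromethyl)phenyl group. The larger group also gives a 1000-fold higher number from compound 3 to compound 4 (3.00 log units; beyond the scatter) and a 10-fold higher number from compound 1 to compound 4 (1.00 log units; beyond the scatter), which extends the earlier reading: all three substituted groups shown on this sulfonyl sulfur give higher numbers than the unsubstituted phenyl, while compound 1 remains lower than compound 2 and compound 4. No measurement available here explains why these groups raise the number or why compound 2 and compound 4 show no separation.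

The compounds shown leave open whether a smaller group on the phenyl ring, such as fluorine, or a methoxy or amine group there would keep the number near that of compound 3 or move it towards those of compound 2 and compound 4. They also leave open whether a short alkyl chain on the sulfonyl sulfur, in place of the aromatic ring, would preserve the low number of compound 3.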